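A few compounds are considered here, and "the series" means these few. Any claim that something is new, unique, unknown or untested is made for them only; others in the source may bear on it.

Working notes on the series.

In a functional assay on PC-3 cells (Homo sapiens) for antiproliferative activity, read by MTT assay, with a stated time of 48 h (on this read-out higher numbers stand for weaker inhibition and lower numbers for stronger inhibition), compound 1 `COc1cccc(-n2cc(COc3ccc(/C=C/C(C)=O)cc3OC)nn2)c1` gives 31600 nM and compound 2 `COc1cc(/C=C/C(C)=O)ccc1OCc1cn(-c2ccc(C=O)cc2)nn1` gives 80700 nM. Among the measured compounds shown here, compound 2 carries the highest number of the two measured in this assay; its nearest neighbour is compound 1, and the single measured step, a 2.6-fold higher number from compound 1 to compound 2 (0.41 log units; beyond the scatter), runs beyond the usual scatter.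

Compound 3 `COc1cc(/C=C/C(C)=O)ccc1OCc1cn(-c2ccccc2O)nn1` is not yet measured. It differs from compound 2 by 2-hydroxyphenyl in place of 4-formylphenyl on an aromatic nitrogen. For the measured compounds named here, the only step that bears on this exchange on the aromatic nitrogen is a 2.6-fold higher number from compound 1 to compound 2 (0.41 log units; beyond the scatter), which shows that the 4-formylphenyl arm gave the higher number of the two. Removing that arm is therefore expected to move the number back down by a modest amount, of the order of the measured step, though a second change of the same size as the scatter would not be surprising. The expected step is a 2.0-fold lower number from compound 2 to compound 3 (0.30 log units; within the scatter) in this assay. Compound 3 is estimated at 40000 nM in this assay, with a range of 15000 nM to 100000 nM.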

Compound 3, half-maximal inhibitory concentration: 59200 nM
Beside the measured number, compound 3's estimate is 1.5-fold (0.17 log units) below it; the measured number falls inside the stated range.
By their numbers in this assay, from the lowest: compounds 1, 3 and 2 (each within the scatter of the next, the first and the last beyond it).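

In this assay, the 2-hydroxyphenyl arm on the aromatic nitrogen cannot be told apart from the 4-formylphenyl arm (a 1.4-fold lower number from compound 2 to compound 3 (0.13 log units; within the scatter)) or from the 3-methoxyphenyl arm (a 1.9-fold higher number from compound 1 to compound 3 (0.27 log units; within the scatter)). Among the compounds shown here, this exchange brings in a hydrogen-bond donor and gives up a double bond outside the aromatic rings, yet neither step leaves the scatter, so the three arms do not yet give this position a clear order beyond the single gap between compound 1 and compound 2. No measurement at hand explains how these arms compare.

From the compounds shown here alone, it remains open whether an aryl arm carrying an amine or a carboxylic acid would give a step beyond the scatter from compound 3. The compounds shown also leave open how an unsubstituted phenyl or a 4-hydroxyphenyl arm would read on this nitrogen.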